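This account rests on a few compounds, and the source may have more. Where it says the series, first, only, none or still open, it means among the compounds named here.

Compound 1 `C[C@@H](c1ccc(NC(=O)N2CC(c3cccnc3)C2)cc1)N1Cc2ccccc2C1=O`: 130000 nM
Compound 2 `C[C@@H](c1ccc(NC(=O)N2CC(c3ccc(N)nc3)C2)cc1)N1Cc2ccccc2C1=O`: 220000 nM

In a physicochemical assay for solubility, read by LC-MS, in phosphate buffer, with a stated time of 24 h, at pH 6.8 (on this read-out higher numbers stand for higher solubility and lower numbers for lower solubility), compound 2 gives 220000 nM, level with compound 1 within the scatter. Compound 3 `C[C@@H](c1ccc(NC(=O)N2CC(c3cncc(N)c3)C2)cc1)N1Cc2ccccc2C1=O` has 5-aminopyridin-3-yl in place of 6-aminopyridin-3-yl on a saturated ring carbon. Among the compounds with values here, the only measured step, a 1.7-fold higher number from compound 1 to compound 2 (0.23 log units; within the scatter), put amino in place of hydrogen on an aromatic carbon and stayed within the scatter. Within the data shown here, no measured pair shows what moving the amino group does. The expected step, a 1.1-fold lower number from compound 2 to compound 3 (0.04 log units; within the scatter), is therefore none beyond the scatter in this assay. For compound 3 the estimated value is 200000 nM, with an expected range of 90000 nM to 400000 nM.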

Compound 3, solubility: 35000 nM
Compound 3: middle estimate off by 5.7-fold (0.76 log units), on the high side, outside the stated range (below it).
By their numbers in this assay, from the lowest: compound 3; then compounds 1 and 2 (each within the scatter of the next).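

In this assay, 5-aminopyridin-3-yl in place of 6-aminopyridin-3-yl gives a 6.3-fold lower number from compound 2 to compound 3 (0.80 log units; beyond the scatter) even though the atoms are the same, so where the amino group sits on this aromatic ring counts. Adding an amino group therefore has no single outcome here: the change gives a 1.7-fold higher number from compound 1 to compound 2 (0.23 log units; within the scatter) in one case and a 3.7-fold lower number from compound 1 to compound 3 (0.57 log units; beyond the scatter) in the other. No measurement shown explains the difference. Still open, as far as these compounds go, is how a methylamino group or a carboxylic acid at either ring position would compare with amino.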